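From a carboxypiperidine to a hydroxypyrrolidine: compound 4 expected

The source may hold more compounds than are shown below. What is called first, only, known or untested is meant among the compounds shown, and "the series" means these compounds.

Compound 1 `COc1ccc(/C=C\c2cc(OC)c(OC)c(OC)c2)cc1OCc1ccc(CN2CCCC[C@H]2C(=O)O)cc1`: > 10000 nM (a limit)
Compound 2 `COc1ccc(/C=C\c2cc(OC)c(OC)c(OC)c2)cc1OCc1ccc(CN2CCCC[C@@H]2C(=O)O)cc1`: > 10000 nM (a limit)
Compound 3 `COc1ccc(/C=C\c2cc(OC)c(OC)c(OC)c2)cc1OCc1ccc(CNCCO)cc1`: 4400 nM

In a functional assay on HeLa cells (Homo sapiens) for antiproliferative activity, read by CCK-8 assay, with a stated time of 48 h (a higher number here means a weaker inhibitor, a lower number a stronger inhibitor), compound 1 reaches only a limit, > 10000 nM. Compound 2 likewise sits at a limit, > 10000 nM. The step that the two limits leave unreadable from compound 1 to compound 2 stays unreadable because of the limit of > 10000 nM in this assay, at which 2 of the 3 values shown sit. Compound 3 gives 4400 nM, which is an at least 2.2-fold lower number from compound 1 to compound 3 (0.35 log units; beyond the scatter) and equally an at least 2.2-fold lower number from compound 2 to compound 3 (0.35 log units; beyond the scatter).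

Compound 4 `COc1ccc(/C=C\c2cc(OC)c(OC)c(OC)c2)cc1OCc1ccc(CN2CC[C@@H](O)C2)cc1` carries 3-hydroxypyrrolidin-1-yl in place of 2-carboxypiperidin-1-yl on a saturated chain carbon bound to an aromatic carbon. Within the data shown here, of the measured steps, only the one from compound 1 to compound 3 bears on it, where the 2-carboxypiperidin-1-yl group also left and a hydroxyl-bearing amine entered. A step of similar size and direction is therefore expected. Compound 4 is estimated at 4000 nM, within 1500 nM to 12000 nM. This estimate means an expected at least 2.5-fold lower number from compound 1 to compound 4 (0.39 log units; beyond the scatter).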

Compound 4, half-maximal inhibitory concentration: > 10000 nM
Compound 4 was reported as a limit (the forecaster's own chance of this, stated with the estimate: 25%); middle value at least 2.5-fold (0.39 log units) from the limit.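

Losing the 2-carboxypiperidin-1-yl group on this saturated chain carbon is therefore not enough on its own: in this assay, 3-hydroxypyrrolidin-1-yl in place of (2-hydroxyethyl)amino gives an at least 2.2-fold higher number from compound 3 to compound 4 (0.35 log units; beyond the scatter). Among the compounds shown, only compound 3, with its (2-hydroxyethyl)amino group, has a value that is not a limit. The steps from compound 1 and from compound 2 to compound 4 cannot be read because of a limit: the limit of > 10000 nM in this assay, at which 3 of the 4 values shown sit.

Going by these compounds, whether the ring or the placing of the hydroxyl separates compound 4 from compound 3 remains open. A plain pyrrolidin-1-yl group or a (3-hydroxypropyl)amino group at this place could help to settle it.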